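The compounds below may be only part of what the source reports. "The series", "measured", "known", "first", "only" and "open" are said of these compounds alone.

Measured in a functional assay on PC-12 cells (Rattus norvegicus) for cytotoxicity, read by MTT assay, with stated times of 2 h and 24 h, tested at 10 uM; a higher number here means a stronger effect of the compound at the concentration tested, a lower number a weaker effect:
- compound 1 `Oc1cc(C(F)(F)F)ccc1-c1nc(-c2ccccc2O)n(-c2ccc(F)cc2)n1`: 99.8%
- compound 2 `COc1ccccc1-n1nc(-c2ccc(C(F)(F)F)cc2O)nc1-c1ccccc1O`: 96.2%

Among the measured compounds shown here, compound 2 holds the smaller of the two numbers, yet the only step, a number 3.6 percentage points lower from compound 1 to compound 2 (within the scatter), is within the scatter, so the two compounds read as indistinguishable in this assay. Compound 3 `Oc1cc(C(F)(F)F)ccc1-c1nc(-c2ccccc2O)n(-c2ccc(F)cc2F)n1` differs from compound 2 by 2,4-difluorophenyl in place of 2-methoxyphenyl on an aromatic nitrogen. For the measured compounds named here, the single step at the same position, a number 3.6 percentage points lower from compound 1 to compound 2 (within the scatter), was within the scatter and both values sit near the ceiling, so for compound 3 no step beyond the scatter is expected, a number 1.8 percentage points higher from compound 2 to compound 3 (within the scatter). Compound 3 is estimated at 98%, range 90% to 100%.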

Compound 3, a percentage reported as activity, at one concentration (the size of the read-out at that concentration, not a potency): 97.9%
Beside the measured number, compound 3's estimate is 0.1 percentage points above it; low and high end bracket the measured number.
By their numbers in this assay, from the lowest: compounds 2, 3 and 1 (each within the scatter of the next).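

In this assay there is a number 1.7 percentage points higher from compound 2 to compound 3 (within the scatter) and 2,4-difluorophenyl reads the same as 2-methoxyphenyl on the aromatic nitrogen, even with the hydrogen-bond acceptor of the leaving group gone. Fluoro in place of hydrogen on an aromatic carbon gives a number 1.9 percentage points lower from compound 1 to compound 3 (within the scatter) and so no separation either. No measurement on hand offers a reason for this flat result.

As far as these compounds go, all three groups on this nitrogen are substituted phenyls, so the effect of an amine, a carboxylic acid or a longer alkyl chain there remains open. A single concentration also leaves any difference in potency among the three unresolved.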